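Benzylamine sulfonamides: para-substituent swap on the benzyl ring

A few compounds are considered here, and "the series" means these few. Any claim that something is new, unique, unknown or untested is made for them only; others in the source may bear on it.

Measured so far:
compound 1 `O=S(=O)(NCCCNCc1ccc(Cl)c(C(F)(F)F)c1)c1cc(C(F)(F)F)cc(C(F)(F)F)c1`, 11000 nM in a functional assay on HT-29 cells (Homo sapiens) for inhibition, read by MTT assay, with a stated time of 72 h; a lower number here means a stronger inhibitor of growth, a higher number a weaker inhibitor of growth
compound 2 `O=S(=O)(NCCCNCc1ccc(C(F)(F)F)cc1)c1cc(C(F)(F)F)cc(C(F)(F)F)c1`, 2900 nM
compound 3 `O=S(=O)(NCCCNCc1ccc(Br)cc1)c1cc(C(F)(F)F)cc(C(F)(F)F)c1`, 2200 nM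

Compound 3 gives the lowest number of the three, though the gap to compound 2 is within the scatter (a 1.3-fold lower number from compound 2 to compound 3 (0.12 log units; within the scatter)); only compound 1 lies clearly apart (a 5.0-fold lower number from compound 1 to compound 3 (0.70 log units; beyond the scatter), a 3.8-fold lower number from compound 1 to compound 2 (0.58 log units; beyond the scatter)).

Compound 4 `COc1ccc(CNCCCNS(=O)(=O)c2cc(C(F)(F)F)cc(C(F)(F)F)c2)cc1` differs from compound 3 by methoxy in place of bromo on an aromatic carbon. Going by the values given here, the one step that bears on it is the para-group exchange, bromo for trifluoromethyl, which moved nothing beyond the scatter; no methoxy analogue exists in the set. The expectation in this assay is therefore a step from compound 3 to compound 4 of a 1.6-fold higher number from compound 3 to compound 4 (0.20 log units; within the scatter), with no clear direction. Compound 4 is estimated at 3500 nM, range 1500 nM to 9000 nM.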

Compound 4, concentration for 50% growth inhibition: 2900 nM
Compound 4: middle estimate off by 1.2-fold (0.08 log units), on the high side, within the range that was stated.
By their numbers in this assay, from the lowest: compounds 3, 2 and 4 (each within the scatter of the next); then compound 1.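

In this assay, methoxy on the aromatic carbon para to a large group gives no step beyond the scatter against bromo (a 1.3-fold higher number from compound 3 to compound 4 (0.12 log units; within the scatter)) or trifluoromethyl (no change at the digits printed from compound 2 to compound 4 (within the scatter)), so a group with a hydrogen-bond acceptor fits the same narrow band as the two without one. Compound 1 stays apart from this third para group as well (a 3.8-fold lower number from compound 1 to compound 4 (0.58 log units; beyond the scatter)). No evidence is available to explain these values. Still open, as far as these compounds go, is how an amine, a carboxylic acid or a nitrile at this position would read.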